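Aromatic Nitrogen Substituent Change on Two Inactive Compounds

The source may hold more compounds than are shown below. What is called first, only, known or untested is meant among the compounds shown, and "the series" means these compounds.

Compound 1 `N#CC1=C(N)Oc2c(c3nc4ccccc4nc3c3ccccc23)C12C(=O)N(Cc1cnnn1-c1cccc(Cl)c1)c1ccccc12`: > 50000 nM
Compound 2 `N#CC1=C(N)Oc2c(N)cc3nc4ccccc4nc3c2C12C(=O)N(Cc1cnnn1-c1ccccc1Cl)c1ccccc12`: > 50000 nM

In an ADME assay on HUVEC cells (Homo sapiens) for antiproliferative activity, read by MTT assay, with a stated time of 48 h (a higher number here means a weaker inhibitor, a lower number a stronger inhibitor), compound 1 gives > 50000 nM, which is a limit of the assay rather than a number. Compound 2 gives > 50000 nM, likewise a limit. Compound 2 therefore stands at the limit of > 50000 nM in this assay, at which 2 of the 2 values shown sit. Compound 3 `COc1ccc(OC)c(-n2nncc2CN2C(=O)C3(C(C#N)=C(N)Oc4c(N)cc5nc6ccccc6nc5c43)c3ccccc32)c1` has not yet been measured in this assay; it differs from compound 2 by 2,5-dimethoxyphenyl in place of 2-chlorophenyl on an aromatic nitrogen. With both measured compounds at the limit, no step beyond the scatter is expected, and compound 3 is expected to remain at the limit. For compound 3 the estimate is 50000 nM, between 20000 nM and 100000 nM, with the expected step of a number no higher from compound 2 to compound 3 (the limit leaves the size open) being essentially none.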

Compound 3, half-maximal inhibitory concentration: > 50000 nM
Compound 3 was reported as a limit (the forecaster's own chance of this, stated with the estimate: 85%); the middle value sits exactly at the limit.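

For the compounds shown here, compound 2 and compound 3 are both reported only as limits in this assay, and no step between them can be read. The compounds shown leave open whether 2,5-dimethoxyphenyl in place of 2-chlorophenyl changes activity at all.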